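A few compounds are considered here, and "the series" means these few. Any claim that something is new, unique, unknown or untested is made for them only; others in the source may bear on it.

Compound 2 `COc1cc2cc(Oc3ccc(NC(=O)Nc4ccc(Cl)c(C(F)(F)F)c4)cc3)c(C)nc2cc1OC` gives 5250 nM in a functional assay on M14 cells (Homo sapiens) for inhibition, read by sulforhodamine B assay, with a stated time of 48 h (a lower number here means a stronger inhibitor of growth, a higher number a weaker inhibitor of growth), and compound 1 `COc1cc2cc(Oc3ccc(NC(=O)Nc4cccc(C(F)(F)F)c4)cc3)c(C)nc2cc1OC` gives 7670 nM in this assay; the two numbers lie within the scatter of each other, so compound 2 is not set apart. Compound 3 `COc1cc2cc(Oc3ccc(NC(=O)Nc4ccc(Cl)c(Cl)c4)cc3)c(C)nc2cc1OC` differs from compound 2 by chloro in place of trifluoromethyl on an aromatic carbon. Among the compounds with values here, the one measured step, a 1.5-fold lower number from compound 1 to compound 2 (0.16 log units; within the scatter), concerns another group at another place, so nothing measured bears directly on this change. Compound 3 is therefore expected to move little, the estimated step being a 1.3-fold higher number from compound 2 to compound 3 (0.12 log units; within the scatter). Compound 3 is estimated at 7000 nM, within a range of 3000 nM to 16000 nM.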

Compound 3, concentration for total growth inhibition: 10500 nM
The estimate for compound 3 lay 1.5-fold (0.18 log units) below the measured number; the range from low to high includes it.
By their numbers in this assay, from the lowest: compounds 2, 1 and 3 (each within the scatter of the next).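

Chloro in place of trifluoromethyl, on the aromatic carbon ortho to a chloro group, gives a 2.0-fold higher number from compound 2 to compound 3 (0.30 log units; within the scatter) in this assay, the first measured step at this position, and this assay does not set the two groups apart here. The wider change to the 3,4-dichlorophenyl group gives a 1.4-fold higher number from compound 1 to compound 3 (0.14 log units; within the scatter), so compound 3 is not set apart from compound 1 either. No other measurement bears on this result. Open, from the compounds shown here alone, is whether an amine or a carboxylic acid on this carbon would give a number beyond the scatter.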